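From a methylpiperazine to a dimethylamino side chain

The source may hold more compounds than are shown below. What is called first, only, known or untested is meant among the compounds shown, and "the series" means these compounds.

Going by the values given here, in a functional assay on MCF7 cells (Homo sapiens) for cytotoxicity, read by MTT assay, with a stated time of 72 h (a higher number here means a weaker inhibitor, a lower number a stronger inhibitor), three compounds built on one shared core have numbers so far. Compound 1 `CCCCN1CCN(CCCCn2c3c(c4ccccc42)C(=O)c2c[n+]([O-])c4ccccc4c2C3=O)CC1` gives 6900 nM, compound 2 `CCCN1CCN(CCCCn2c3c(c4ccccc42)C(=O)c2c[n+]([O-])c4ccccc4c2C3=O)CC1` gives 1280 nM, and compound 3 `CN1CCN(CCCn2c3c(c4ccccc42)C(=O)c2c[n+]([O-])c4ccccc4c2C3=O)CC1` gives 220 nM, the lowest number of the three and so the strongest inhibitor among them.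

Compound 4 `CN(C)CCCCn1c2c(c3ccccc31)C(=O)c1c[n+]([O-])c3ccccc3c1C2=O` alters the side chain of compound 3: (dimethylamino)methyl in place of 4-methylpiperazin-1-yl on a saturated chain carbon, three bonds along the chain from an aromatic nitrogen. Read one bond further out, 3-(4-methylpiperazin-1-yl)propyl becomes 4-(dimethylamino)butyl.

Among the compounds with values here, three measured steps bear on this. There is a modest 5.4-fold lower number from compound 1 to compound 2 (0.73 log units; beyond the scatter), a modest 5.8-fold lower number from compound 2 to compound 3 (0.76 log units; beyond the scatter) and a large 31-fold lower number from compound 1 to compound 3 (1.50 log units; beyond the scatter). Across these three compounds, a smaller side chain went with a lower number, and none goes against that trend. None of the steps, however, replaces the ring with an open amine, so the guidance is loose. The group entering compound 4 is smaller than the one leaving, which suggests a lower number, but its side chain is longer, which suggests a higher one.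

With these two pulls opposed, no clear step is expected in this assay. The expected change is a 1.4-fold higher number from compound 3 to compound 4 (0.13 log units; within the scatter), which would not lie beyond the usual scatter. Compound 4 is estimated at 300 nM, with an expected range of 90 nM to 1000 nM.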

Compound 4, half-maximal inhibitory concentration: 220 nM
The estimate for compound 4 lay 1.4-fold (0.13 log units) above the measured number; low and high end bracket the measured number.
By their numbers in this assay, from the lowest: compounds 3 and 4 (each within the scatter of the next); then compound 2; then compound 1.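

In this assay, exchanging the 3-(4-methylpiperazin-1-yl)propyl chain for 4-(dimethylamino)butyl gives no change at the digits printed from compound 3 to compound 4 (within the scatter), so the ring is not needed here to reach this level, provided the open amine sits on the butyl chain. With the butyl chain held fixed, changing only the end group to dimethylamino gives a 5.8-fold lower number from compound 2 to compound 4 (0.76 log units; beyond the scatter) and a 31-fold lower number from compound 1 to compound 4 (1.50 log units; beyond the scatter), which shows that the end group alone can move the number well beyond the scatter; compound 4 nevertheless goes against the earlier link between a smaller side chain and a lower number, since its smaller group does not take it past compound 3. No supporting data are available to explain these results.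

The step from compound 3 to compound 4 alters ring and chain length together, so the contribution of each remains unresolved, and a 3-(dimethylamino)propyl chain or a 4-(4-methylpiperazin-1-yl)butyl chain on the shared core would separate them. From the compounds shown here alone, whether the open amine tolerates anything larger also remains open, as a diethylamino end group on the butyl chain would show.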